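Swapping Phenyl for Allyl on an Amide-Type Nitrogen

A few compounds are considered here, and "the series" means these few. Any claim that something is new, unique, unknown or untested is made for them only; others in the source may bear on it.

In a functional assay on the whole organism (stomach) with Rattus norvegicus as the target (on this read-out higher numbers stand for an effect only at larger amounts of compound and lower numbers for an effect already at smaller amounts), compound 1 `S=C(Nc1ccccc1)C1(c2ccccn2)CCCS1` gives > 30 mg/kg, which is a limit of the assay and not a number. Compound 2 `OCC/N=C(\S)C1(c2ccccn2)CCCS1` gives > 30 mg/kg, which is also a limit. Compound 3 `C=CCNC(=S)C1(c2ccccn2)CCCS1` keeps the core of compound 1 but carries allyl in place of phenyl on an amide-type nitrogen. Among the measured compounds shown here, no measured step shows what such a swap does, so this expectation is uncertain. The expected change in this assay is a number no higher from compound 1 to compound 3 (the limit leaves the size open), with no step beyond the scatter. Compound 3 is estimated at 30 mg/kg, with an expected range from 10 mg/kg to 90 mg/kg.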

Compound 3, dose for half-maximal effect: > 30 mg/kg
Compound 3: a limit, no number; the forecaster's own chance of this, stated with the estimate: 60%; the middle value lies on the limit itself.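

Among the compounds shown here, compound 1 and compound 3 both end at a limit of the assay, so swapping phenyl for allyl gives no step that can be read. What dose any of these compounds needs for half-maximal effect stays open: the limit of > 30 mg/kg in this assay, at which 3 of the 3 values shown sit.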